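A few compounds are considered here, and "the series" means these few. Any claim that something is new, unique, unknown or untested is made for them only; others in the source may bear on it.

Of the compounds shown here, two have been measured in a functional assay for inhibition of sodium/hydrogen exchanger (Oryctolagus cuniculus); on this read-out higher numbers stand for weaker inhibition and lower numbers for stronger inhibition. Compound 1 `CS(=O)(=O)c1cc(C(=O)N=C(N)N)c(Cl)cc1Cl` gives 140 nM. Compound 2 `Cc1cc(C)c(S(C)(=O)=O)cc1C(=O)N=C(N)N` gives 11 nM, the lower of the two numbers, and the gap to compound 1 lies beyond the usual scatter, so compound 2 is the stronger inhibitor of the pair. Compound 3 `Cc1cc(C2CCC2)c(S(C)(=O)=O)cc1C(=O)N=C(N)N` has not yet been measured; it differs from compound 2 by cyclobutyl in place of methyl on an aromatic carbon. Within the data shown here, no measured pair shows this change, so the step is expected to be small, within the scatter, with a 1.6-fold lower number from compound 2 to compound 3 (0.20 log units; within the scatter). Compound 3 is estimated at 7 nM, with a range from 2 nM to 30 nM.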

Compound 3, half-maximal inhibitory concentration: 8.2 nM
For compound 3 the middle estimate is 1.2-fold (0.07 log units) below the measured one; the measured number falls inside the stated range.
By their numbers in this assay, from the lowest: compounds 3 and 2 (each within the scatter of the next); then compound 1.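

Putting cyclobutyl in place of methyl on this aromatic carbon gives a 1.3-fold lower number from compound 2 to compound 3 (0.13 log units; within the scatter) in this assay, so the two compounds cannot be told apart. This position, ortho to the methylsulfonyl group, therefore takes a four-membered ring of carbon where a single methyl stood, with the number staying within the scatter. Nothing at hand explains this result. Still open, on these data alone, is how an amine or a carboxylic acid on this carbon would read, and whether a longer chain or a larger ring such as cyclohexyl fits equally well.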